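The source may hold more compounds than are shown below. What is called first, only, known or untested is meant among the compounds shown, and "the series" means these compounds.

Values measured in an ADME assay on Vero cells (Chlorocebus sabaeus) for inhibition (on this read-out higher numbers stand for lower toxicity in this test and lower numbers for higher toxicity in this test), so far

Compound 1 (`COc1ccc(/C=C2\CCC/C(=C\c3ccccc3)C2=O)cc1`): 291000 nM
Compound 2 (`COc1ccc(/C=C2\CCC/C(=C\c3ccc(N(C)C)cc3)C2=O)cc1`): 392000 nM

For the measured compounds named here, compound 1 has only one measured neighbour, compound 2, and their two numbers lie within the scatter of each other, so the two stand level. Still unmeasured is compound 3 (`COc1ccc(/C=C2\CCC/C(=C\c3ccccc3F)C2=O)cc1`), which keeps the core of compound 1 and carries fluoro in place of hydrogen on an aromatic carbon, taking phenyl to 2-fluorophenyl (fluoro in place of hydrogen on an aromatic carbon). Going by the values given here, only one measured step bears on this change. It puts dimethylamino in place of hydrogen on an aromatic carbon, and it amounts to a 1.3-fold higher number from compound 1 to compound 2 (0.13 log units; within the scatter) in the same test. Among the compounds with values here, that step involves a different group, so it is only a loose guide, and no measured compound yet carries fluoro. On this evidence, no step beyond the scatter is expected in this assay, in either direction. The expected step is a 1.0-fold lower number from compound 1 to compound 3 (0.00 log units; within the scatter), a small one. For compound 3 the estimated value is 290000 nM, with an expected range from 140000 nM to 550000 nM.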

Compound 3, half-maximal cytotoxic concentration: 270000 nM
Beside the measured number, compound 3's estimate is 1.1-fold (0.03 log units) above it; the range from low to high includes it.
By their numbers in this assay, from the lowest: compounds 3, 1 and 2 (each within the scatter of the next).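

In this assay, for the compounds shown here, the step of a 1.1-fold lower number from compound 1 to compound 3 (0.03 log units; within the scatter) gives the first reading for a ring carbon ortho to a large group, a place the earlier pair of compounds did not test. Together with the dimethylamino step a 1.3-fold higher number from compound 1 to compound 2 (0.13 log units; within the scatter), it means that two quite different groups placed on this phenyl ring each leave the number within the usual scatter of compound 1, so in this small set neither change registers in this toxicity test. That statement covers only fluoro at this one place and dimethylamino, and nothing measured here offers an explanation for either result.

Fluoro adds just one heavy atom, so it remains open whether a bulkier or differently built group at the same ring carbon, such as a bromo, a nitrile, a carboxylic acid or a longer alkyl chain, would also stay within the scatter. Also open, on these data alone, is whether a change to the methoxy group on the other aromatic ring, or to the shared core, would move the number beyond the scatter in this test.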